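The compounds below may be only part of what the source reports. "The series", "measured", "known", "first", "only" and "open" are said of these compounds alone.

Compound 1 `Cc1oc(=O)oc1COC(=O)N1C[C@@H]2C[C@H]1C(=O)Nc1cccc(c1)C(=O)OCc1oc(=O)oc1COC(=O)C1=C(S2)[C@H](C)[C@@H]2[C@@H]([C@@H](C)O)C(=O)N12`, compound 2 `CCOC(=O)C1=C(S[C@H]2C[C@@H](C(=O)Nc3cccc(C(=O)OCC)c3)N(C(=O)OCc3oc(=O)oc3C)C2)[C@H](C)[C@@H]2[C@@H]([C@@H](C)O)C(=O)N12` and compound 3 `CCOC(=O)C1=C(S[C@@H]2CN[C@H](C(=O)Nc3cccc(C(=O)OCC)c3)C2)[C@H](C)[C@@H]2[C@@H]([C@@H](C)O)C(=O)N12` were measured, while compound 4 `C[C@@H](O)[C@H]1C(=O)N2C3=C(S[C@@H]4CN[C@@H](C4)C(=O)Nc4cccc(c4)C(=O)OCc4oc(=O)oc4COC3=O)[C@H](C)[C@H]12` has not yet been. The core of compound 1 and the core shared by compound 2 and compound 3 differ in a way that is not broken down here. In an ADME assay for metabolic stability, read by LC-MS, with a stated time of 3 h, at pH 6.5, tested at 50 uM (on this read-out lower numbers stand for a less stable compound and higher numbers for a more stable compound), compound 1 gives > 95%, which is a limit of the assay. In this assay compound 2 gives > 95%, also a limit. In this assay compound 3 gives > 95%, again a limit. From compound 2 to compound 3 the change is a hydrogen atom in place of a group of 11 heavy atoms (6 carbon, 5 oxygen; one five-membered aromatic ring with 2 hetero atoms), on an amine nitrogen in a ring, and the step that the two limits leave unreadable from compound 2 to compound 3 cannot be read because of the limit of > 95% in this assay, at which 3 of the 3 values shown sit. Compound 4 arises from compound 1 by a hydrogen atom in place of a group of 11 heavy atoms (6 carbon, 5 oxygen; one five-membered aromatic ring with 2 hetero atoms), on an amine nitrogen in a ring, the same kind of change, though here the nitrogen ring is part of a fused or bridged system of six rings and sits next to the ring atom that bears a fused ring rather than a large group. Compound 4 is expected to show a step that the limit leaves unreadable from compound 1 to compound 4, because compound 1 gives > 95%, a limit. In this assay compound 4 is estimated at 96%.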

Compound 4, percent of the compound remaining: > 95%
Compound 4: a limit, no number; the forecaster's own chance of this, stated with the estimate: 0.8%; the middle value does not contradict the limit.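

No new step can be read from compound 1 to compound 4, because both values are limits: the limit of > 95% in this assay, at which 4 of the 4 values shown sit. The compounds shown leave open whether any of the four truly differ from one another in this assay.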